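A few compounds are considered here, and "the series" means these few. Any claim that something is new, unique, unknown or untested is made for them only; others in the source may bear on it.

In a functional assay on SAOS-2 cells (Homo sapiens) for antiproliferative activity, read by MTT assay, with a stated time of 72 h (on this read-out lower numbers stand for stronger inhibition and higher numbers for weaker inhibition), the three measured compounds stand as follows.
Compound 1 `CC(C)OC1=C(C(=O)c2ccccc2)C(c2ccc(Br)cc2)N(CCCn2ccnc2)C1=O` gives 23000 nM.
Compound 2 `O=C(C1=C(OC2CCCCC2)C(=O)N(CCCn2ccnc2)C1c1ccc(Br)cc1)c1ccccc1` gives 29700 nM.
Compound 3 `CCOc1ccc(NC2=C(C(=O)c3ccccc3)C(c3ccc(Br)cc3)N(CCCn3ccnc3)C2=O)cc1` gives 30900 nM.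

Compound 3 has the highest of the three numbers, but its steps from the others, a 1.3-fold higher number from compound 1 to compound 3 (0.13 log units; within the scatter) and a 1.0-fold higher number from compound 2 to compound 3 (0.02 log units; within the scatter), lie within the scatter, so no order among the three can be drawn. Compound 4 `O=C(C1=C(Nc2cccc(Br)c2)C(=O)N(CCCn2ccnc2)C1c1ccc(Br)cc1)c1ccccc1` differs from compound 3 in one place: 3-bromophenyl in place of 4-ethoxyphenyl on an amine nitrogen. Every measured step altered the group on the double-bonded ring carbon, namely a 1.3-fold higher number from compound 1 to compound 2 (0.11 log units; within the scatter), a 1.3-fold higher number from compound 1 to compound 3 (0.13 log units; within the scatter) and a 1.0-fold higher number from compound 2 to compound 3 (0.02 log units; within the scatter), and none moved the number beyond the scatter. For the measured compounds named here, no measured step exchanges one substituent of the phenyl on the amine nitrogen for another, so this change is untested; the numbers so far have barely moved. Compound 4 is therefore expected to give 30000 nM, between 12000 nM and 75000 nM, an estimated step of a 1.0-fold lower number from compound 3 to compound 4 (0.01 log units; within the scatter) that stays within the scatter.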

Compound 4, half-maximal inhibitory concentration: 9090 nM
Estimate against measurement, compound 4: 3.3-fold (0.52 log units) above, outside the stated range (below it).
By their numbers in this assay, from the lowest: compound 4; then compounds 1, 2 and 3 (each within the scatter of the next).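

In this assay, the group on the amine nitrogen proves able to move the number: 3-bromophenyl in place of 4-ethoxyphenyl gives a step beyond the scatter (a 3.4-fold lower number from compound 3 to compound 4 (0.53 log units; beyond the scatter)), unlike every earlier step. (3-Bromophenyl)amino on the double-bonded ring carbon also separates from cyclohexyloxy (a 3.3-fold lower number from compound 2 to compound 4 (0.51 log units; beyond the scatter)) and from isopropoxy (a 2.5-fold lower number from compound 1 to compound 4 (0.40 log units; beyond the scatter)), whereas the earlier groups at this place stayed within the scatter of one another. Nothing available explains this result.

The compounds shown leave open whether the bromine itself or its place on the phenyl carries this step. A 4-bromophenyl or a 3-ethoxyphenyl on the amine nitrogen would tell these apart.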